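Moving the methoxy group around the benzyl ring

The source may hold more compounds than are shown below. What is called first, only, known or untested is meant among the compounds shown, and "the series" means these compounds.

Measured so far in a functional assay on CHO-K1 cells for antagonist activity at prostaglandin E2 receptor EP1 subtype (Homo sapiens), read by FLIPR and calcium flux; a lower number here means a stronger inhibitor, a higher number a weaker inhibitor:
- compound 1, `CCc1ccccc1N(CC(=O)NCc1cccc(OC)c1)S(=O)(=O)c1ccc(C)cc1`: 138 nM
- compound 2, `CCc1ccccc1N(CC(=O)NCc1ccc(Cl)cc1)S(=O)(=O)c1ccc(C)cc1`: 11.5 nM
- compound 3, `CCc1ccccc1N(CC(=O)NCc1ccc(Br)cc1)S(=O)(=O)c1ccc(C)cc1`: 22.9 nM

Compound 1 gives the highest of the three numbers. The nearest to it is compound 3, reached by a 6.0-fold lower number from compound 1 to compound 3 (0.78 log units; beyond the scatter); the furthest is compound 2, reached by a 12-fold lower number from compound 1 to compound 2 (1.08 log units; beyond the scatter). Between those two halogen analogues the difference is a 2.0-fold higher number from compound 2 to compound 3 (0.30 log units; within the scatter), so they cannot be ordered.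

Compound 4, `CCc1ccccc1N(CC(=O)NCc1ccccc1OC)S(=O)(=O)c1ccc(C)cc1`, has not been measured. It differs from compound 1 by 2-methoxyphenyl in place of 3-methoxyphenyl on a saturated chain carbon bound to an amide-type nitrogen.

For the measured compounds named here, none of the measured steps covers this change. Going by the values given here, the steps from compound 1 to compound 2 and to compound 3 show that replacing the 3-methoxyphenyl by a halogenated ring moves the number a long way, but both swap the methoxy group for a halogen at a different place; no measured pair keeps the methoxy group and moves it. The expectation for compound 4 therefore has to stay close to compound 1, with a wide range in either direction. Compound 4 is estimated at 150 nM, with a likely range from 45 nM to 500 nM, which corresponds to an expected step of a 1.1-fold higher number from compound 1 to compound 4 (0.04 log units; within the scatter), inside the usual scatter.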

Compound 4, inhibition constant: 1070 nM
Estimate against measurement, compound 4: 7.1-fold (0.85 log units) below, outside the stated range (above it).
By their numbers in this assay, from the lowest: compounds 2 and 3 (each within the scatter of the next); then compound 1; then compound 4.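

Moving the methoxy group alone, with the atoms unchanged, shifts the result in this assay (a 7.8-fold higher number from compound 1 to compound 4 (0.89 log units; beyond the scatter)), so the earlier contrast between methoxy and halogen rings was not the only change at this position that matters: where the methoxy group sits counts by itself. The same change widens the gap to the halogenated compounds (a 47-fold higher number from compound 3 to compound 4 (1.67 log units; beyond the scatter) and a 93-fold higher number from compound 2 to compound 4 (1.97 log units; beyond the scatter)), and as all three steps lie beyond the scatter, compound 4 is the weakest inhibitor of the four shown. No available measurement bears on why the two methoxy placements differ.

The compounds shown leave open how an unsubstituted phenyl on the same chain carbon would compare, so it cannot be said whether either methoxy placement raises or lowers the number relative to a ring with no group on it. They also leave open whether a halogen responds to being moved as the methoxy group does, since chloro and bromo appear here only as 4-chlorophenyl and 4-bromophenyl.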